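The source may report more compounds than this note shows. Statements on the series, on what has been measured and on what is new or still open speak of the compounds shown alone.

Of the compounds shown here, three have been measured so far in a functional assay on MCF7 cells (Homo sapiens) for inhibition; on this read-out lower numbers stand for stronger inhibition and higher numbers for weaker inhibition. Compound 1 `CNc1ncnc2c1ncn2C1O[C@H](CO)[C@@](C)(O)[C@H]1O` gives 68100 nM, a measured number, though a large one on this scale. Compound 2 `C[C@@]1(O)[C@@H](CO)OC(n2cnc3c(N)nc(Cl)nc32)[C@@H]1O` reads > 100000 nM, which is a limit of the assay and not a number. Compound 3 `CNc1ncnc2c1ncn2C1O[C@H](CO)[C@@H](O)[C@@]1(C)O` reads > 100000 nM, which is likewise a limit. Compound 3 therefore stands at the limit of > 100000 nM in this assay, at which 2 of the 3 values shown sit.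

Compound 4 `C[C@]1(O)C(n2cnc3c(NC4CC4)ncnc32)O[C@H](CO)[C@H]1O` differs from compound 3 in one group: cyclopropyl in place of methyl on a nitrogen on an aromatic ring. Cyclopropyl takes the place of methyl on a nitrogen on an aromatic ring, so methylamino becomes cyclopropylamino.

Going by the values given here, no two measured compounds differ in one place only, so the data offer no direct measure of what this kind of change does. The main anchor is compound 3, whose > 100000 nM is a limit, and it gives no sign of measurable inhibition to build on. A change no larger than the usual scatter is therefore expected in this assay, with no direction favoured. The expected step is a number no higher from compound 3 to compound 4 (the limit leaves the size open). Compound 4 is estimated at 100000 nM, with an expected range from 30000 nM to 300000 nM.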

Compound 4, half-maximal inhibitory concentration: > 100000 nM
Compound 4 gave a limit, no number (the forecaster's own chance of this, stated with the estimate: 65%); the middle value lies on the limit itself.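

Compound 3 and compound 4 both end at a limit of this assay and not at a number, and no step can be read between them: the limit of > 100000 nM in this assay, at which 3 of the 4 values shown sit.

The compounds shown leave open whether cyclopropyl in place of methyl on a nitrogen on an aromatic ring changes inhibition in this assay at all.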